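Compound 4: a pyrrolidine chain end in place of the amide

This account rests on a few compounds, and the source may have more. Where it says the series, first, only, none or still open, it means among the compounds named here.

Compound 1 (`Cn1ncc(Cl)c1-c1cc(C(=O)N[C@@H]2CN[C@H](CCNS(C)(=O)=O)C[C@H]2c2ccc(F)c(F)c2)oc1Cl`): 920 nM
Compound 2 (`Cn1ncc(Cl)c1-c1cc(C(=O)N[C@@H]2CN[C@H](CCO)C[C@H]2c2ccc(F)c(F)c2)oc1Cl`): 360 nM
Compound 3 (`Cn1ncc(Cl)c1-c1cc(C(=O)N[C@@H]2CN[C@H](CC(N)=O)C[C@H]2c2ccc(Cl)c(Cl)c2)oc1Cl`): 650 nM

These numbers come from a functional assay on HCT-116 cells (Homo sapiens) for antiproliferative activity, read by sulforhodamine B assay, with a stated time of 72 h (on this read-out higher numbers stand for weaker inhibition and lower numbers for stronger inhibition), and describe three close relatives. Compound 3 lies within the scatter of each of the other two, so it holds no clear rank among them. Compound 4 (`Cn1ncc(Cl)c1-c1cc(C(=O)N[C@@H]2CN[C@H](CCN3CCCC3)C[C@H]2c2ccc(Cl)c(Cl)c2)oc1Cl`) differs from compound 3 in one place, with (pyrrolidin-1-yl)methyl in place of carbamoyl on a saturated chain carbon bound to a saturated ring carbon, and (pyrrolidin-1-yl)methyl in place of carbamoyl on a saturated chain carbon bound to a saturated ring carbon gives the full count.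

Among the measured compounds shown here, no measured compound carries this new group. For the measured compounds named here, the only guide is a 2.6-fold lower number from compound 1 to compound 2 (0.41 log units; beyond the scatter) for hydroxy in place of methanesulfonamido on the same chain, a modest step that gives a size but no direction for the new change. In this assay a step no larger than that is therefore expected, quite possibly none beyond the scatter. The expected step is a 1.4-fold lower number from compound 3 to compound 4 (0.16 log units; within the scatter) on this reasoning. Compound 4 is therefore estimated at 450 nM (expected range 150 nM to 1300 nM).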

Compound 4, half-maximal inhibitory concentration: 1940 nM
Compound 4: middle estimate off by 4.3-fold (0.63 log units), on the low side, and the stated range ends below it.
By their numbers in this assay, from the lowest: compounds 2, 3 and 1 (each within the scatter of the next, the first and the last beyond it); then compound 4.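

In this assay, the step of a 3.0-fold higher number from compound 3 to compound 4 (0.47 log units; beyond the scatter) shows that the saturated chain carbon bound to a saturated ring carbon can carry a change that raises the number beyond the scatter, a direction the earlier step on this chain, a 2.6-fold lower number from compound 1 to compound 2 (0.41 log units; beyond the scatter), did not show. This single pair replaces carbamoyl, with one hydrogen-bond donor, by (pyrrolidin-1-yl)methyl, with none and with a five-membered non-aromatic ring, so the donor and the ring change together and cannot be separated. Nothing available explains the rise in the number.

The compounds shown leave open whether a dimethylamino group, a morpholine ring or a carboxylic acid at the chain end would give a number closer to that of compound 3 or of compound 4. They also leave open whether the same replacement would produce a step of similar size on the core of compound 1.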